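Changing the Halogen Pattern on the Benzyl Group

A few compounds are considered here, and "the series" means these few. Any claim that something is new, unique, unknown or untested is made for them only; others in the source may bear on it.

Measured compounds:
Compound 1, `Ic1ccc(Cn2cc(CCCOc3cccc4cccnc34)nn2)cc1`: 24.7 ug/mL
Compound 2, `Fc1ccc(Cn2cc(CCCOc3cccc4cccnc34)nn2)cc1`: 20.1 ug/mL

Both numbers come from a functional assay on PC-3 cells (Homo sapiens) for inhibition, read by sulforhodamine B assay, with a stated time of 48 h; a lower number here means a stronger inhibitor of growth, a higher number a weaker inhibitor of growth. Among the measured compounds shown here, compound 1 holds the higher of the two, but its only neighbour is compound 2, and the step of a 1.2-fold lower number from compound 1 to compound 2 (0.09 log units; within the scatter) sits inside the scatter, so the two are not really told apart. Compound 3, `Clc1ccc(Br)cc1Cn1cc(CCCOc2cccc3cccnc23)nn1`, is not yet measured. It differs from compound 1 in one place: 5-bromo-2-chlorophenyl in place of 4-iodophenyl on a saturated chain carbon bound to an aromatic nitrogen. For the measured compounds named here, the single measured step, a 1.2-fold lower number from compound 1 to compound 2 (0.09 log units; within the scatter), exchanges one halogen for another on that ring and moves nothing beyond the scatter. The change to compound 3 keeps a halogenated ring in the same place but alters the pattern, for which no measured guide exists. The expected step is therefore a 1.1-fold lower number from compound 1 to compound 3 (0.03 log units; within the scatter), nothing beyond the scatter. Compound 3 is estimated at 23 ug/mL, in a range from 10 ug/mL to 50 ug/mL.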

Compound 3, concentration for 50% growth inhibition: 8.2 ug/mL
Beside the measured number, compound 3's estimate is 2.8-fold (0.45 log units) above it; the measured number lies below the stated range.
By their numbers in this assay, from the lowest: compound 3; then compounds 2 and 1 (each within the scatter of the next).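

In this assay this position turns out to be able to shift the number: exchanging one halogen for another on the ring gave no resolved difference, but moving to 5-bromo-2-chlorophenyl gives a 3.0-fold lower number from compound 1 to compound 3 (0.48 log units; beyond the scatter) and also a 2.5-fold lower number from compound 2 to compound 3 (0.39 log units; beyond the scatter) in the same direction. Both steps are modest yet beyond the scatter, so compound 3 is the strongest inhibitor of growth among the three shown. No measured information here explains this difference.

Still open is whether the 5-bromo or the 2-chloro part accounts for the shift, or whether the two are needed together, as no ring carrying only one of them at these places appears among the compounds shown. Also open, on these data alone, is how a plain phenyl, a methoxy group or an amine on the ring would read in this test.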